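The source may hold more compounds than are shown below. What is called first, only, known or untested is meant among the compounds shown, and "the series" means these compounds.

Of the compounds shown here, two have so far been measured in an assay for inhibition of Amine oxidase [flavin-containing] A (Bos taurus), read by fluorescence, with a stated time of 60 min; a lower number here means a stronger inhibitor, a higher number a weaker inhibitor. Compound 1 `O=C(NNc1nc2ccccc2nc1Cc1ccccc1)c1ccccc1` gives 78 nM in this assay. Compound 2 `O=C(Cn1c(=O)c(Cc2ccccc2)nc2ccccc21)NNC(=O)c1ccc(Cl)cc1` gives 64 nM, the lower of the two numbers, though its gap to compound 1 lies within the scatter, so neither compound can be placed above the other. Compound 3 `O=C(Cn1c(=O)c(Cc2ccccc2)nc2ccccc21)N/N=C1/C(=O)Nc2ccccc21` has not yet been measured; it differs from compound 2 in a single place: a group of 11 heavy atoms (8 carbon, 2 nitrogen, 1 oxygen; one five-membered non-aromatic ring with 1 hetero atom, one six-membered aromatic ring of carbon only) in place of a group of 10 heavy atoms (7 carbon, 1 nitrogen, 1 oxygen, 1 chlorine; one six-membered aromatic ring of carbon only), on an amide-type nitrogen. The amide-type nitrogen keeps its carbonyl carbon neighbour, and the shared core is otherwise untouched. Among the compounds with values here, no measured pair shows a step of this kind, so the size of the effect is open; the two values in hand lie close together, and nothing here points to a large shift in either direction. Compound 3 is therefore expected to give about 80 nM, with a range from 25 nM to 250 nM. The expected step of a 1.3-fold higher number from compound 2 to compound 3 (0.10 log units; within the scatter) is thus small, within or near the scatter.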

Compound 3, half-maximal inhibitory concentration: 7.3 nM
For compound 3 the middle estimate is 11-fold (1.04 log units) above the measured one, and the stated range ends above it.
By their numbers in this assay, from the lowest: compound 3; then compounds 2 and 1 (each within the scatter of the next).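

In this assay, within the data shown here, the exchange of the ((4-chlorophenyl)carbonyl)amino group on the amide-type nitrogen for the group holding a five-membered non-aromatic ring gives an 8.8-fold lower number from compound 2 to compound 3 (0.94 log units; beyond the scatter) and is the first change here to move the number beyond the scatter. The value therefore responds to what stands at this place, which the close values of the two earlier compounds could not show. No evidence given here bears on why the number falls. The step changes several things at once: the chlorine leaves, a second ring enters, and the count of hydrogen-bond acceptors rises, so the compounds shown cannot assign it to any one of these. Going by these compounds, it also remains open whether a fluorine, a methoxy group or an amine on the benzene ring of the entering group would keep the number this low.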